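Trifluoromethyl on the fused core of compound 1

This account rests on a few compounds, and the source may have more. Where it says the series, first, only, none or still open, it means among the compounds named here.

Measured compounds:
- compound 1, `COc1ccc(Cn2c(C(=O)O)c(CNCc3cccc(OC)c3)c3ccccc32)cc1`: 52900 nM
- compound 2, `COc1ccc(Cn2c(C(=O)O)c(CNCc3ccc(O)c(OC)c3)c3ccccc32)cc1`: > 50000 nM
- compound 3, `COc1cccc(CNCc2c(C(=O)O)n(Cc3ccccc3)c3ccccc23)c1`: > 50000 nM

Going by the values given here, in a functional assay on Bel-7402 cells (Homo sapiens) for antiproliferative activity, read by MTT assay, with a stated time of 72 h (on this read-out higher numbers stand for weaker inhibition and lower numbers for stronger inhibition), compound 1 gives 52900 nM, the only number in the set. For compound 2 the result in this assay is a limit of the assay, > 50000 nM, and not a number. For compound 3 the result in this assay is likewise a limit, > 50000 nM. Both steps away from compound 1, a step that the limit leaves unreadable from compound 1 to compound 2 and a step that the limit leaves unreadable from compound 1 to compound 3, are therefore of unreadable size; what can be said is the limit of > 50000 nM in this assay, at which 2 of the 3 values shown sit.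

The unmeasured compound 4, `COc1ccc(Cn2c(C(=O)O)c(CNCc3cccc(OC)c3)c3ccc(C(F)(F)F)cc32)cc1`, differs from compound 1 by trifluoromethyl in place of hydrogen on an aromatic carbon, the change sitting on the fused or bridged system of two rings of the shared core. Among the compounds with values here, no measured step touches this part of the core, so no step bears on it, and the two measured steps from compound 1 give no readable size at all. In this assay compound 4 is therefore expected to stay close to compound 1, with a step of a 1.3-fold lower number from compound 1 to compound 4 (0.12 log units; within the scatter) that is within the scatter. The estimate for compound 4 is 40000 nM, in a range from 15000 nM to 100000 nM, with a fair chance that only a limit is reported.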

Compound 4, half-maximal inhibitory concentration: > 50000 nM
Compound 4: only a limit was reported; the forecaster's own chance of this, stated with the estimate: 40%; at least 1.2-fold (0.09 log units) between middle value and limit.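

In this assay compound 4 gives > 50000 nM, a limit and not a number, so the step from compound 1 to compound 4 cannot be read. The compounds shown leave open what size the change to trifluoromethyl on the shared core has, with the series resting largely on a single mark: the limit of > 50000 nM in this assay, at which 3 of the 4 values shown sit.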